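Swapping the Aryl Group for a Methylpiperazine

This account rests on a few compounds, and the source may have more. Where it says the series, first, only, none or still open, it means among the compounds named here.

For the measured compounds named here, in a functional assay on A549 cells (Homo sapiens) for inhibition, read by MTT assay, with a stated time of 72 h (a lower number here means a stronger inhibitor, a higher number a weaker inhibitor), compound 2 (`CN(C)c1ccc(-c2cc(C(=O)N3CCC4(CC3)CC(=O)c3nn(C(C)(C)C)cc3O4)c3ccccc3n2)cc1`) holds the lower of the two numbers so far, with 1150 nM as its value, while compound 1 (`CC(C)(C)n1cc2c(n1)C(=O)CC1(CCN(C(=O)c3cc(-c4ccc(F)cc4)nc4ccccc34)CC1)O2`) gives 5770 nM as its value. Going by the values given here, the only measured step, a 5.0-fold lower number from compound 1 to compound 2 (0.70 log units; beyond the scatter) for dimethylamino in place of fluoro on an aromatic carbon, is modest but beyond the scatter.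

Compound 3 (`CN1CCN(c2cc(C(=O)N3CCC4(CC3)CC(=O)c3nn(C(C)(C)C)cc3O4)c3ccccc3n2)CC1`) carries 4-methylpiperazin-1-yl in place of 4-(dimethylamino)phenyl on an aromatic carbon, next to the ring nitrogen: 4-methylpiperazin-1-yl in place of 4-(dimethylamino)phenyl on an aromatic carbon. Among the compounds with values here, no measured compound lacks the aromatic ring that this change removes, so the evidence is indirect. Within the data shown here, the single step above shows only that a change within this group, a 5.0-fold lower number from compound 1 to compound 2 (0.70 log units; beyond the scatter) in size, can move the number beyond the scatter. A shift of similar modest size seems reasonable, and the direction is more likely upward, away from the low number of compound 2 at 1150 nM in this assay. The expected change is a 2.6-fold higher number from compound 2 to compound 3 (0.42 log units; beyond the scatter) with considerable uncertainty. For compound 3 the estimated value is 3000 nM within an expected range of 800 nM to 12000 nM overall.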

Compound 3, half-maximal inhibitory concentration: > 10000 nM
Compound 3 gave a limit, no number; the forecaster's own chance of this, stated with the estimate: 10%; middle value at least 3.3-fold (0.52 log units) from the limit.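

In this assay compound 3 gives only a limit and not a number, so its true value stays unknown, and this is the one reading of its kind among the compounds shown: the limit of > 10000 nM in this assay, at which 1 of the 3 values shown sits.

Even so, placing 4-methylpiperazin-1-yl instead of 4-(dimethylamino)phenyl on the aromatic carbon next to the ring nitrogen gives an at least 8.6-fold higher number from compound 2 to compound 3 (0.93 log units; beyond the scatter), which shows that a nitrogen-bearing group at this position does not by itself keep the lower number of compound 2. Set against the fluoro compound, the same position gives a less sharp result: 4-methylpiperazin-1-yl in place of 4-fluorophenyl gives an at least 1.7-fold higher number from compound 1 to compound 3 (0.23 log units; that floor lies within the scatter), so the limit does not separate these two compounds beyond the scatter.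

The change removes the six-membered aromatic ring of carbon only and brings in the non-aromatic ring in a single step, so the compounds shown cannot say which of the two matters more. A morpholin-4-yl ring, or a 4-(4-methylpiperazin-1-yl)phenyl group that keeps the aromatic ring, on the same carbon would pull those two apart.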